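From an allyl group to a 3-(dimethylamino)propyl chain

This account rests on a few compounds, and the source may have more. Where it says the series, first, only, none or still open, it means among the compounds named here.

compound 1 `CCC(=O)N(c1ccccc1C)C1CCCC1N(C)C` value > 50 mg/kg
compound 2 `C=CCN(C)C1CCCC1N(C(=O)CC)c1ccc(Cl)c(Cl)c1` value 6 mg/kg

In a functional assay on the whole organism for positive allosteric modulation, with Mus musculus as the target (a lower number here means that less compound is needed, a higher number that more compound is needed for the effect), compound 1 gives > 50 mg/kg as a limit, not a number. For the measured compounds named here, compound 2 gives 6 mg/kg as the only actual number so far in this assay for this pair of compounds.

Compound 3 `CCC(=O)N(c1ccc(Cl)c(Cl)c1)C1CCCC1N(C)CCCN(C)C` departs from compound 2 by 2-(dimethylamino)ethyl in place of vinyl on a saturated chain carbon bound to an amine nitrogen in one place. In words, 2-(dimethylamino)ethyl stands in place of vinyl on a saturated chain carbon bound to an amine nitrogen, which turns allyl into 3-(dimethylamino)propyl. Going by the values given here, no measured pair isolates this change, and the expectation is therefore loose. A moderate move toward more compound being needed is expected, and a reading that gives only a limit remains possible. The estimated change is a 3.3-fold higher number from compound 2 to compound 3 (0.52 log units; beyond the scatter) in that direction. Compound 3 is estimated at 20 mg/kg with 7 mg/kg to 50 mg/kg as the expected range.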

Compound 3, dose for half-maximal effect: 30 mg/kg
For compound 3 the middle estimate is 1.5-fold (0.18 log units) below the measured one, and the stated range covers the measured number.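

In this assay, for the compounds shown here, replacing allyl with 3-(dimethylamino)propyl gives a 5.0-fold higher number from compound 2 to compound 3 (0.70 log units; beyond the scatter), the first reading of any change on a saturated chain carbon bound to an amine nitrogen. This place therefore accepts a longer chain ending in a further amine, although more compound is needed for the effect. Compound 3 still gives a number rather than a limit, so this change does not take the series to the edge of the assay's reading: the limit of > 50 mg/kg in this assay, at which 1 of the 3 values shown sits.

Going by these compounds alone, the single step cannot separate the effect of the longer chain from that of its terminal dimethylamino group, and a plain butyl chain in the same place would help to tell them apart. As far as these compounds go, how a terminal hydroxyl or carboxylic acid on this chain would read also remains open.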